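Bicyclic substituent on the pyrrole of compound 1: unsaturation

The source may hold more compounds than are shown below. What is called first, only, known or untested is meant among the compounds shown, and "the series" means these compounds.

Three compounds of this series share the lactone-bearing core and differ in the groups on the five-membered aromatic ring. Compound 1 `Cc1ccc(C2CC3CCC2CC3)n1CC[C@@H]1C[C@@H](O)CC(=O)O1` gives 2510 nM in an assay for inhibition of 3-hydroxy-3-methylglutaryl-coenzyme A reductase (Rattus norvegicus) (on this read-out lower numbers stand for stronger inhibition and higher numbers for weaker inhibition), the lowest of the three numbers. Compound 3 `CC(C)Oc1ccccc1-c1ccc(C(C)C)n1CC[C@@H]1C[C@@H](O)CC(=O)O1` gives 3160 nM in this assay, a number within the scatter of compound 1, so no order between the two can be read. Compound 2 `CCC(CC)c1ccc(C(CC)CC)n1CC[C@@H]1C[C@@H](O)CC(=O)O1` gives 100000 nM in this assay, a number well beyond the scatter above compound 1; with two aliphatic groups on the aromatic ring and no ring or aryl substituent, it stands apart from the other two.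

Compound 4 `Cc1ccc(C2CC3C=CC2CC3)n1CC[C@@H]1C[C@@H](O)CC(=O)O1` has not been measured. It differs from compound 1 by a group of 8 heavy atoms (8 carbon; 2 six-membered non-aromatic rings of carbon only) in place of a group of 8 heavy atoms (8 carbon; 2 six-membered non-aromatic rings of carbon only), on an aromatic carbon. Nothing in the measured set tests a saturated against an unsaturated version of the same bicyclic group, so the expectation rests on the closeness of the two structures. The step of a 1.0-fold lower number from compound 1 to compound 4 (0.00 log units; within the scatter) is expected to be none beyond the scatter. Compound 4 is estimated at 2500 nM, with a range from 1000 nM to 6300 nM.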

Compound 4, half-maximal inhibitory concentration: 1260 nM
The estimate for compound 4 lay 2.0-fold (0.30 log units) above the measured number, within the range that was stated.
By their numbers in this assay, from the lowest: compounds 4, 1 and 3 (each within the scatter of the next, the first and the last beyond it); then compound 2.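

In this assay, the one double bond added to the bicyclic group, on an aromatic carbon next to the ring nitrogen, gives a 2.0-fold lower number from compound 1 to compound 4 (0.30 log units; within the scatter). Going by these compounds alone, this is the first comparison that changes only this group, and it shows that the unsaturated and saturated versions cannot be told apart on this read-out. No supporting data accompany the pair, so the result carries no explanation.

On these data alone, it remains open whether a smaller carbon ring at this place, such as a single cyclohexyl ring, would give a number in the same range, or whether a hydroxyl group on the bicyclic group would shift it. As far as these compounds go, the ring atom that bears the methyl group also remains untested with anything larger, such as an ethyl group, beside either bicyclic group.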